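The source may report more compounds than this note shows. Statements on the series, on what has been measured and on what is new or still open speak of the compounds shown alone.

Of the compounds shown here, three have so far been measured in an assay on HEK293 cells for inhibition of transient receptor potential cation channel subfamily V member 6 (Homo sapiens), read by FLIPR, with a stated time of 5 min; on this read-out higher numbers stand for weaker inhibition and lower numbers for stronger inhibition. Compound 1, `O=C1O[B-](c2ccccc2)(c2ccccc2)[NH2+][C@H]1CO`, gives 20200 nM in this assay. Compound 2, `OB(c1ccc(F)cc1)c1ccc(F)cc1`, gives 61600 nM. Compound 3, `Cc1ccc([B-]2(c3ccccc3)[NH2+]CCO2)cc1`, gives 12900 nM, the lowest of the three numbers; its gap to compound 1 lies within the usual scatter of repeated measurements, whereas its gap to compound 2 lies beyond it, so compound 3 can be set apart from compound 2 but not from compound 1.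

Compound 4, `Brc1ccc([B-]2(c3ccccc3)[NH2+]CCO2)cc1`, has not yet been measured. It differs from compound 3 in a single place: bromo in place of methyl on an aromatic carbon. Within the data shown here, no pair among the measured compounds shows this exchange, so there is no measured step to lean on, and the expectation rests only on the close kinship of the two structures and on the value of compound 3. The step from compound 3 to compound 4 in this assay is therefore expected to be small, without a firm direction, and most likely none beyond the scatter: a 1.2-fold lower number from compound 3 to compound 4 (0.07 log units; within the scatter). In this assay compound 4 is expected to give about 11000 nM, with a range from 4000 nM to 30000 nM.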

Compound 4, half-maximal inhibitory concentration: 9800 nM
Compound 4: the middle estimate sits 1.1-fold (0.05 log units) above what was measured; low and high end bracket the measured number.
By their numbers in this assay, from the lowest: compounds 4, 3 and 1 (each within the scatter of the next, the first and the last beyond it); then compound 2.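

Among these compounds, the first step that can be read at this position, bromo in place of methyl on an aromatic carbon para to a large group, comes to a 1.3-fold lower number from compound 3 to compound 4 (0.12 log units; within the scatter) in this assay. This exchange of one heavy atom for another, with no hydrogen-bond donor or acceptor entering or leaving and no net charge on either group, therefore gives no number that can be set apart from the one before it, so on this core and in this assay the position accepts either methyl or bromo without a difference that can be read. No independent evidence bears on this result, so the step stands as an observation without an explanation.

Going by these compounds, with only these two groups compared at this position, it remains open whether a methoxy group, a nitrile, an amine or a carboxylic acid in the same place would give a step beyond the scatter. On these data alone, it is also open whether bromo in place of methyl would give an equally small step at another aromatic carbon of the shared core or on a different core.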